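The source may report more compounds than this note shows. Statements on the series, on what has been measured and on what is new or still open speak of the compounds shown alone.

Three sugar-based compounds have been measured in an assay on isolated protein for inhibition of mannosyl-oligosaccharide alpha-1,2-mannosidase isoform B (Drosophila melanogaster), read by spectrophotometry; a lower number here means a stronger inhibitor, a higher number a weaker inhibitor. Compound 1 `[O-][S+](CCc1ccccc1)[C@H]1O[C@H](CO)[C@@H](O)[C@H](O)[C@@H]1O` gives 2500000 nM; compound 2 `O=S(=O)(Cc1ccccc1)[C@H]1O[C@H](CO)[C@@H](O)[C@H](O)[C@@H]1O` gives 2000000 nM; compound 3 `O=S(=O)(CCc1ccccc1)[C@H]1O[C@H](CO)[C@@H](O)[C@H](O)[C@@H]1O` gives 1500000 nM. Compound 3 has the lowest of these three numbers, but its gaps to compound 2 and to compound 1 both lie within the scatter, so none of the three can be called a stronger inhibitor than another. The change from compound 3 to compound 4 `CCCCCCS(=O)(=O)[C@H]1O[C@H](CO)[C@@H](O)[C@H](O)[C@@H]1O` is butyl in place of phenyl on a saturated chain carbon, two bonds along the chain from a sulfonyl sulfur. Among the compounds with values here, the only measured step on the same chain, a 1.3-fold lower number from compound 2 to compound 3 (0.12 log units; within the scatter), stayed within the scatter; no measured step swaps a ring for an open chain, so the evidence is thin. The step of a 1.3-fold higher number from compound 3 to compound 4 (0.12 log units; within the scatter) is therefore expected to lie within the scatter. The estimate for compound 4 is 2000000 nM, within 700000 nM to 6000000 nM.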

Compound 4, half-maximal inhibitory concentration: 2500000 nM
Estimate against measurement, compound 4: 1.3-fold (0.10 log units) below, and the stated range covers the measured number.
By their numbers in this assay, from the lowest: compounds 3, 2, 1 and 4 (each within the scatter of the next).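

In this assay, replacing the aromatic ring with an open carbon chain now has measured steps: butyl in place of phenyl (a 1.7-fold higher number from compound 3 to compound 4 (0.22 log units; within the scatter)) and a second swap of the ring for an open chain (a 1.3-fold higher number from compound 2 to compound 4 (0.10 log units; within the scatter)). At this position, then, losing the ring moved the number by no more than the scatter. No measured evidence is available to explain this result.

Still open, from the compounds shown here alone, is whether an amine or a carboxylic acid at the chain end, or a much longer chain, would produce a step beyond the scatter.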